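This account rests on a few compounds, and the source may have more. Where it says the series, first, only, none or still open, it means among the compounds named here.

Working notes on the series. All three measured compounds share one core and differ only in the group attached to it. Compound 1 `O=C(O)CC1COc2cc(OCc3ncc(-c4ccccc4)o3)ccc21` and compound 2 `O=C(O)CC1COc2cc(OCc3cc(-c4ccccc4)on3)ccc21` carry five-membered heteroaromatic groups on the ether; in a functional assay on CHO cells for agonist activity at Free fatty acid receptor 1 (Homo sapiens), read by FLIPR and calcium flux, tested at 100 nM (a lower number here means a weaker effect, a higher number a stronger effect of the compound at the concentration tested), compound 1 gives 2.34% and compound 2 gives 0.84%. Compound 3 `Cc1nc(-c2ccc(Cl)s2)sc1COc1ccc2c(c1)OCC2CC(=O)O` gives 8.34% in this assay, the highest of the three numbers, though its gap to compound 1 and its gap to compound 2 both fall within the usual scatter, so no order among the three can be read from these values. For the measured compounds named here, no single-point step between the measured compounds is available.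

Compound 4 `Cc1nc(-c2ccccc2F)sc1COc1ccc2c(c1)OCC2CC(=O)O` is the next member, not yet measured. It differs from compound 3 in one place: 2-fluorophenyl in place of 5-chlorothiophen-2-yl on an aromatic carbon. Going by the values given here, nothing in the measured set isolates the effect of this exchange, and every value so far sits close to the bottom of the range. On that basis the step from compound 3 to compound 4 is expected to be small, a number 2.3 percentage points lower from compound 3 to compound 4 (within the scatter), not beyond the scatter in either direction. Compound 4 is therefore estimated to give 6% in this assay, with an expected range from 0% to 18%.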

Compound 4, a percentage reported as activity, at one concentration (the size of the read-out at that concentration, not a potency): 25.8%
The estimate for compound 4 lay 19.8 percentage points below the measured number, outside the stated range (above it).
By their numbers in this assay, from the lowest: compounds 2, 1 and 3 (each within the scatter of the next); then compound 4.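

For the compounds shown here, the aryl group on this aromatic carbon of the five-membered ring, next to the ring nitrogen and next to the ring sulfur, is the first place where a single exchange moves the read-out beyond the scatter: in this assay, 2-fluorophenyl in place of 5-chlorothiophen-2-yl gives a number 17.5 percentage points higher from compound 3 to compound 4 (beyond the scatter). The earlier compounds offered no single-place step, so this position had not been shown to respond at all, and it now does, with the methyl group, the ether link and the shared core held constant. The exchange alters the ring size, removes the ring sulfur and replaces chlorine with fluorine all at once, and no measurement at hand explains the step or assigns it to any one of these parts.

Still open, on these data alone, is whether the rise follows the six-membered ring or the fluorine, a question that a 2-chlorophenyl or a 2-methoxyphenyl group at this position would begin to separate. Also open, as far as these compounds go, is whether a pyridin-2-yl group, which keeps a six-membered ring but brings a ring nitrogen, would hold the higher read-out seen for compound 4 in this assay.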